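Trifluoromethyl removed from the aryl triazole of compound 1

The compounds below may be only part of what the source reports. "The series", "measured", "known", "first", "only" and "open" are said of these compounds alone.

Working notes on the series. Among the measured compounds shown here, compound 1 `C=C1C(=O)[C@]23C[C@@]1(O)CC[C@H]2c1ccc(O)c(C)c1[C@@H]3Cn1cc(-c2ccc(C(F)(F)F)cc2)nn1` is the only member with a number in a functional assay on HL-60 cells (Homo sapiens) for cytotoxicity, read by MTT assay, with a stated time of 4 days; on this read-out higher numbers stand for weaker inhibition and lower numbers for stronger inhibition: compound 1 gives 720 nM. Compound 2 `Cc1ccc(S(=O)(=O)Oc2ccc3c(c2C)[C@H](Cn2cc(-c4ccc(Br)cc4)nn2)[C@@]24CC(=O)[C@@](C)(CC[C@@H]32)C4)cc1` reaches only a limit of this assay, reported as > 20000 nM. Compound 3 `C=C1C[C@]23C[C@@]1(O)CC[C@H]2c1ccc(O)c(C)c1[C@@H]3Cn1cc(-c2ccc(F)cc2)nn1` likewise reaches only a limit of this assay, reported as > 20000 nM. For the measured compounds named here, two of the three values therefore sit at the limit of > 20000 nM in this assay, at which 2 of the 3 values shown sit, and no pair of measured compounds differs in a single place, so no measured step is available to calibrate the change considered here.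

Compound 4 `C=C1C(=O)[C@]23C[C@@]1(O)CC[C@H]2c1ccc(O)c(C)c1[C@@H]3Cn1cc(-c2ccccc2)nn1` differs from compound 1 in one place: hydrogen in place of trifluoromethyl on an aromatic carbon. The measured compounds give no direct read on what losing the trifluoromethyl does, since the two compounds at the limit differ from compound 1 in more than this group alone. The expectation for compound 4 is a step of a 2.1-fold higher number from compound 1 to compound 4 (0.32 log units; beyond the scatter) from compound 1, a modest move toward weaker inhibition, with a real chance that it stays within the scatter. Compound 4 is therefore estimated at 1500 nM in this assay, with a range from 500 nM to 6000 nM, and some chance that only a limit is returned.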

Compound 4, half-maximal inhibitory concentration: 750 nM
Beside the measured number, compound 4's estimate is 2.0-fold (0.30 log units) above it; low and high end bracket the measured number.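

In this assay the series now holds its first measured step between compounds that differ in one place: a 1.0-fold higher number from compound 1 to compound 4 (0.02 log units; within the scatter). In this pair the trifluoromethyl on the aromatic carbon is not needed to keep the number of compound 1, and the phenyl of compound 4 cannot be told apart from the 4-(trifluoromethyl)phenyl of compound 1. This reading rests on one pair only and does not extend to the rest of the series, where the other compounds give no number to set against it: the limit of > 20000 nM in this assay, at which 2 of the 4 values shown sit.

Among the compounds shown here, whether an amine, a carboxylic acid or a longer chain on the same aromatic carbon would also leave the number unmoved remains open, as the single step covers only hydrogen and trifluoromethyl. Going by these compounds, compound 2 and compound 3 each differ from compound 1 and from compound 4 in more than one place, the steps to them cannot be read, and what the carbonyl of the core contributes also remains open.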